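The compounds below may be only part of what the source reports. "The series", "measured", "known", "first", "only" and "open" are said of these compounds alone.

Compound 1 `ClCc1ccccc1Cn1cnc2c(Cl)nc(Cl)nc21`: 4570 nM
Compound 2 `Nc1nc(Cl)c2ncn(Cc3ccc(CCl)cc3)c2n1`: 44700 nM
Compound 3 `ClCc1cccc(Cn2cnc3c(Cl)nc(Cl)nc32)c1`: 5620 nM

Of the compounds shown here, three that share the same core have been tested in a functional assay on U-251 cells (Homo sapiens) for cytotoxicity, read by sulforhodamine B assay, with a stated time of 48 h; on this read-out lower numbers stand for higher toxicity in this test and higher numbers for lower toxicity in this test. Compound 1 gives the lowest number of the three, 4570 nM. Compound 3 gives 5620 nM, a number within the scatter of that for compound 1, so these two cannot be told apart on this read-out. Compound 2 gives 44700 nM, a number clearly higher than that of compound 1 and beyond the scatter. Compound 2 differs from compound 1 in more than one place, so its value alone cannot say which change is responsible.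

Compound 4 `Nc1nc(Cl)c2ncn(Cc3ccccc3CCl)c2n1` has not yet been tested in this assay. It differs from compound 1 in a single place: amino in place of chloro on an aromatic carbon. Within the data shown here, no pair of measured compounds shows this change on its own. Still, compound 2 carries the same amino group and gives 44700 nM, the highest number in the set, and that is the only hint available. On that hint, the step expected here is a 5.5-fold higher number from compound 1 to compound 4 (0.74 log units; beyond the scatter), a rise in the number beyond the scatter. For compound 4 the value in this assay is therefore estimated at 25000 nM, with a range from 8000 nM to 70000 nM.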

Compound 4, concentration lethal to 50% of the cells: 72400 nM
Estimate against measurement, compound 4: 2.9-fold (0.46 log units) below, outside the stated range (above it).
By their numbers in this assay, from the lowest: compounds 1 and 3 (each within the scatter of the next); then compounds 2 and 4 (each within the scatter of the next).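

Changing chloro to amino on the aromatic carbon between two ring nitrogen atoms, with the rest of the molecule unchanged, gives a 16-fold higher number from compound 1 to compound 4 (1.20 log units; beyond the scatter) in this assay, a large step that points to lower toxicity in this test. Among these compounds, this is the first reading of this change on its own, and it shows that this single position can strongly affect the result, whereas the value for compound 2 could not be tied to any one of its differences from compound 1; compound 2 and compound 4 both carry the amino group, and their numbers lie within the scatter of each other. Nothing available here explains why the step is so large.

From the compounds shown here alone, it remains open whether a methylamino group, a methoxy group or a plain hydrogen on this same carbon would give a number closer to that of compound 1 or to that of compound 4. Going by these compounds, it is also open whether the amino group would produce a step of similar size on compound 3, where the chloromethyl group sits elsewhere on the benzene ring.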